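From nitro to trifluoromethoxy at a sensitive position

The source may hold more compounds than are shown below. What is called first, only, known or untested is meant among the compounds shown, and "the series" means these compounds.

In a functional assay on MDA-MB-231 cells (Homo sapiens) for inhibition, read by sulforhodamine B assay, with a stated time of 74 h (on this read-out higher numbers stand for weaker inhibition and lower numbers for stronger inhibition), compound 1 (`Cc1ccc(S(=O)(=O)N2C(=O)COC23C=CC(=O)C=C3)cc1`) gives 70 nM. Compound 2 (`CS(=O)(=O)N1C(=O)COC12C=CC(=O)C=C2`) gives > 10000 nM, which is a limit of the assay. Compound 3 (`O=C1C=CC2(C=C1)OCC(=O)N2S(=O)(=O)c1ccc([N+](=O)[O-])cc1`) gives > 10000 nM, also a limit and not a number. Compound 3 therefore has no exact value and sits with compound 2 at the limit of > 10000 nM in this assay, at which 2 of the 3 values shown sit.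

Compound 4 (`O=C1C=CC2(C=C1)OCC(=O)N2S(=O)(=O)c1ccc(OC(F)(F)F)cc1`) keeps the shared core and carries trifluoromethoxy in place of nitro on an aromatic carbon. Within the data shown here, two measured steps bear on this change, and both are large. Methyl in place of 4-methylphenyl on a sulfonyl sulfur gives an at least 140-fold higher number from compound 1 to compound 2 (2.15 log units; beyond the scatter). Nitro in place of methyl gives an at least 140-fold higher number from compound 1 to compound 3 (2.15 log units; beyond the scatter), and this second step concerns the same aromatic carbon. Removing the nitro group may therefore recover part of that loss, though compound 4 does not carry the methyl of compound 1.

A clear move to a lower number is expected, with the estimated size being an at least 10-fold lower number from compound 3 to compound 4 (1.00 log units; beyond the scatter). For compound 4 the estimate is 1000 nM, with an expected range from 80 nM to 10000 nM.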

Compound 4, half-maximal inhibitory concentration: > 10000 nM
Compound 4: no number, only a limit (the forecaster's own chance of this, stated with the estimate: 30%); at least 10-fold (1.00 log units) between middle value and limit.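

Compound 3 and compound 4 both stand at a limit in this assay, and the step between them cannot be read. The new information comes from the comparison with compound 1: trifluoromethoxy in place of methyl on this aromatic carbon gives an at least 140-fold higher number from compound 1 to compound 4 (2.15 log units; beyond the scatter), so the large loss seen with nitro is not confined to nitro. Of the three groups shown on this carbon, only the methyl of compound 1 gives a number, and the others join compound 2 at the top of the range: the limit of > 10000 nM in this assay, at which 3 of the 4 values shown sit.

From the compounds shown here alone, how far compound 3 and compound 4 lie beyond that limit remains unknown, as does whether activity at this position depends on methyl itself. An ethyl group, a chlorine atom or a methoxy group on the same aromatic carbon would test how narrow this requirement is.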